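A Single Ring Stereocentre Inverted in Compound 2

The source may hold more compounds than are shown below. What is called first, only, known or untested is meant among the compounds shown, and "the series" means these compounds.

Among the measured compounds shown here, compound 2 `O=C(c1ccc(O)cc1O)[C@H]1[C@H](C(=O)c2ccc(O)cc2O)[C@H](c2ccccc2)[C@@H]1c1ccccc1` stands highest of the two compounds measured so far in a functional assay on PC-3 cells (Homo sapiens) for cytotoxicity, read by MTT assay, with a stated time of 48 h, tested at 25 uM; a higher number here means a stronger effect of the compound at the concentration tested, a lower number a weaker effect: compound 2 gives 87.6%, while compound 1 `O=C(c1ccc(O)cc1O)[C@@H]1[C@@H](C(=O)c2ccc(O)cc2O)[C@H](c2ccccc2)[C@@H]1c1ccccc1` gives 75.5%. For the measured compounds named here, the one measured step is a number 12.1 percentage points higher from compound 1 to compound 2 (beyond the scatter), and the only thing that separates these two is the fact that compounds 1 and 2 differ only in the configuration as drawn, with every atom and bond shared between them.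

Going by the values given here, compound 3 `O=C(c1ccc(O)cc1O)[C@H]1[C@H](C(=O)c2ccc(O)cc2O)[C@@H](c2ccccc2)[C@@H]1c1ccccc1` has not yet been measured. the two compounds have the same atoms and bonds and differ only in configuration as drawn: 1 of 4 stereo elements differ; a stereocentre at a saturated ring carbon is drawn R in compound 2 and S in compound 3 The step of a number 12.1 percentage points higher from compound 1 to compound 2 (beyond the scatter) is the single guide to how this change might play out: it shows that configuration alone can shift the read-out beyond the scatter, but that step altered two centres, whereas the move to compound 3 alters one. A step of modest size is therefore expected for compound 3, its direction uncertain, and the likelier outcome is a value close to or somewhat under that of its parent. The estimate for compound 3 is 80%, with a range from 62% to 95%, which amounts to an expected a number 7.6 percentage points lower from compound 2 to compound 3 (within the scatter).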

Compound 3, a percentage reported as activity, at one concentration (the size of the read-out at that concentration, not a potency): 97.6%
Compound 3: middle estimate off by 17.6 percentage points, on the low side, and the stated range ends below it.
By their numbers in this assay, from the lowest: compound 1; then compounds 2 and 3 (each within the scatter of the next).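

In this assay, inverting the single saturated ring carbon, drawn R in compound 2 and S in compound 3, gives a number 10 percentage points higher from compound 2 to compound 3 (within the scatter), so this one centre on its own does not move the read-out past the scatter, and the comparison is a clean one: the fact that compounds 2 and 3 differ only in the configuration as drawn. Changing three of the four stereo elements gives a number 22.1 percentage points higher from compound 1 to compound 3 (beyond the scatter), which does lie past the scatter, and here too nothing else separates the pair: the fact that compounds 1 and 3 differ only in the configuration as drawn. Together with the earlier step, this sets compound 1 apart from both compound 2 and compound 3, while the new centre adds no separation of its own that can be told from the scatter.

Going by these compounds, the fourth stereo element is drawn the same in all three compounds, so what its inversion would do remains open, as does whether compound 2 and compound 3 would separate in a true potency measure rather than a read-out at one concentration. Also open is how an amine or a carboxylic acid added to the shared core would behave in this assay, since every compound shown carries the same atoms and bonds.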